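Extending a propargyl arm into an ester-bearing chain

This account rests on a few compounds, and the source may have more. Where it says the series, first, only, none or still open, it means among the compounds named here.

Compound 1 `N#CCN(Cc1ccc2ccccc2c1)Cc1ccccc1Br` and compound 2 `C#CCN(Cc1ccccc1)Cc1ccc2ccccc2c1` share a common core built around an amine nitrogen. In an assay on HEK293 cells for binding affinity to Substance-K receptor (Rattus norvegicus), read by FRET, tested at 10 uM (a lower number here means less inhibition, a higher number more inhibition at the concentration tested (going by the name of the read-out)), compound 1 gives 0%. In this assay compound 2 gives 0%, level with compound 1 at the digits shown, within the scatter. Compound 3 `CCOC(=O)CCCCN(Cc1ccccc1)Cc1ccc2ccccc2c1` differs from compound 2 by 3-(ethoxycarbonyl)propyl in place of ethynyl on a saturated chain carbon bound to an amine nitrogen. For the measured compounds named here, no step between measured compounds is known here, and the two values offer no direction to build on. Compound 3 is expected to show a step of a number 2 percentage points higher from compound 2 to compound 3 (within the scatter), none beyond the scatter. Compound 3 is therefore estimated to give 2%, with a range from -8% to 15%.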

Compound 3, a percentage reported as inhibition, at one concentration (the size of the read-out at that concentration, not a potency): 0%
Beside the measured number, compound 3's estimate is 2 percentage points above it, within the range that was stated.
By their numbers in this assay, from the lowest: compounds 1, 2 and 3 (each within the scatter of the next).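

In this assay there is no change at the digits printed from compound 2 to compound 3 (within the scatter) when 3-(ethoxycarbonyl)propyl takes the place of ethynyl on a saturated chain carbon bound to an amine nitrogen. For the compounds shown here, this is the first step that can be read at this position, and a group of 8 heavy atoms with 2 hydrogen-bond acceptors leaves the read-out where ethynyl, with 2 heavy atoms and no acceptors, had it. Nothing available explains this result.

On these data alone, whether a carboxylic acid, an amine or a longer chain at this position would give any inhibition remains open.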